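The source may hold more compounds than are shown below. What is called first, only, known or untested is meant among the compounds shown, and "the series" means these compounds.

Among the compounds with values here, compound 3 `C=CC(=O)Nc1cccc(NC(=O)CSc2nc(Nc3cccc(F)c3)c3ccccc3n2)c1` gives 8160 nM in a functional assay on MDA-MB-231 cells (Homo sapiens) for inhibition, read by MTT assay, with a stated time of 72 h (on this read-out higher numbers stand for weaker inhibition and lower numbers for stronger inhibition), the lowest of the three numbers so far. Compound 2 `O=C(CSc1nc(Nc2ccccc2)c2ccccc2n1)Nc1ccc(Cl)cc1Cl` gives 19400 nM in this assay, and compound 1 `O=C(CSc1nc(Nc2ccccc2)c2ccccc2n1)Nc1ccccc1Cl` gives 24400 nM; both gaps to compound 3 lie beyond the scatter. Compound 4 `C=CC(=O)Nc1cccc(NC(=O)CSc2nc(Nc3ccc(Br)cc3)c3ccccc3n2)c1` differs from compound 3 by 4-bromophenyl in place of 3-fluorophenyl on a nitrogen on an aromatic ring. Within the data shown here, no measured pair isolates a change on that nitrogen; the only single-point step available, a 1.3-fold lower number from compound 1 to compound 2 (0.10 log units; within the scatter), concerns a different part of the molecule and falls within the scatter. With nothing bearing directly on this change, no move beyond the scatter is expected. Compound 4 is therefore expected near 8000 nM, with a range from 3500 nM to 18000 nM. The expected step in this assay is a 1.0-fold lower number from compound 3 to compound 4 (0.01 log units; within the scatter).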

Compound 4, half-maximal inhibitory concentration: 17300 nM
Estimate against measurement, compound 4: 2.2-fold (0.33 log units) below; the range from low to high includes it.
By their numbers in this assay, from the lowest: compound 3; then compounds 4, 2 and 1 (each within the scatter of the next).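

Within the data shown here, on the nitrogen on an aromatic ring, this assay now gives a first step for this position: 4-bromophenyl in place of 3-fluorophenyl gives a 2.1-fold higher number from compound 3 to compound 4 (0.33 log units; beyond the scatter). This position is therefore not silent, although the change swaps the halogen and its place on the phenyl ring together, and this single step cannot separate the two. Nothing at hand explains the step. Still open, from the compounds shown here alone, is how 3-bromophenyl or 4-fluorophenyl would read, which would part the halogen from its place. Also open, going by these compounds, is whether a methoxy group or an amine on this phenyl ring would give a number lower than that of compound 3.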